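Aryl ketone side chain: methoxy to fluoro

The compounds below may be only part of what the source reports. "The series", "measured", "known", "first", "only" and "open" are said of these compounds alone.

Compound 2 `COc1ccc(C(=O)CSc2nnc(-c3cc(OC)c(OC)c(OC)c3)n2N2C(=O)c3ccccc3C2=O)cc1` holds the only numerical read-out in the set; in a functional assay on HepG2 cells (Homo sapiens) for cytotoxicity, read by MTT assay, with a stated time of 48 h (on this read-out higher numbers stand for weaker inhibition and lower numbers for stronger inhibition), compound 2 gives 28700 nM. Compound 1 `COc1cc(-c2nnc(SCc3ccccc3)n2N2C(=O)c3ccccc3C2=O)cc(OC)c1OC` gives only a limit of the assay, > 200000 nM, which is the limit of > 200000 nM in this assay, at which 1 of the 2 values shown sits. Among the compounds with values here, the single measured step, an at least 6.9-fold lower number from compound 1 to compound 2 (0.84 log units; beyond the scatter), exchanges the whole group on the saturated chain carbon bound to a sulfur. Compound 3 `COc1cc(-c2nnc(SCC(=O)c3ccc(F)cc3)n2N2C(=O)c3ccccc3C2=O)cc(OC)c1OC` differs from compound 2 by fluoro in place of methoxy on an aromatic carbon. No measured step touches a substituent on that six-membered ring; the one step shown concerns the presence of the (4-methoxyphenyl)carbonyl group itself, so it offers no direct guide. With the aryl ketone retained, the number for compound 3 is expected to stay within the scatter of compound 2, a 1.0-fold higher number from compound 2 to compound 3 (0.02 log units; within the scatter). Compound 3 is therefore estimated at 30000 nM, in the range 10000 nM to 90000 nM.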

Compound 3, half-maximal inhibitory concentration: > 200000 nM
Compound 3: a limit, no number (the forecaster's own chance of this, stated with the estimate: 10%); at least 6.6-fold (0.82 log units) between middle value and limit.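

Fluoro in place of methoxy on the aryl ketone gives an at least 6.9-fold higher number from compound 2 to compound 3 (0.84 log units; beyond the scatter) in this assay, so a substituent on this ring can decide whether a number is reached at all. The aryl ketone alone is therefore not enough: compound 3 keeps it, and of the three compounds only compound 2, with the 4-methoxyphenyl group, gives a number. Compound 3 gives a limit and not a number, as does compound 1, so the step between them cannot be read: the limit of > 200000 nM in this assay, at which 2 of the 3 values shown sit.

Open, on these data alone, is whether the number depends on methoxy specifically, which a hydroxy group, a methyl group or an amine at the same place on the ring would test. Also open, as far as these compounds go, is how the step from compound 1 to compound 2 divides between the carbonyl and the methoxy, which a 4-methoxybenzyl group on the sulfur would begin to separate.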